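This account rests on a few compounds, and the source may have more. Where it says the series, first, only, none or still open, it means among the compounds named here.

Measured in a functional assay on cells for agonist activity at C-X-C chemokine receptor type 4 (Homo sapiens), read by fluorescence and calcium flux, with a stated time of 90 s; a higher number here means that more compound is needed for the effect, a lower number that less compound is needed:
Compound 1, `c1ccc2c(c1)CN[C@@H](CN(CCCCNC1CCCCC1)[C@H]1CCCc3cccnc31)C2`, gives > 30000 nM, a limit of the assay.
Compound 2, `c1ccc2c(c1)CN[C@@H](CN(CCCCNC1CCOCC1)[C@H]1CCCc3cccnc31)C2`, gives > 30000 nM, also a limit of the assay.

Within the data shown here, compound 2 stands only at a limit in this assay, and the single other value shown sits there as well, as the limit of > 30000 nM in this assay, at which 2 of the 2 values shown sit, records. The step that the two limits leave unreadable from compound 1 to compound 2 is accordingly unreadable. Compound 3, `c1ccc2c(c1)CN[C@@H](CN(CCCCNC1CCNCC1)[C@H]1CCCc3cccnc31)C2`, carries the change (piperidin-4-yl in place of oxan-4-yl on an amine nitrogen). Among the measured compounds shown here, no measured step is readable here, so no direction for this assay can be taken from the data. Compound 3 is expected to remain at the limit too, an estimated step that the limit leaves unreadable from compound 2 to compound 3. The estimate for compound 3 is 40000 nM, with a range from 10000 nM to 150000 nM.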

Compound 3, half-maximal effective concentration: > 30000 nM
Compound 3 ended at the assay's limit; the forecaster's own chance of this, stated with the estimate: 80%; the middle value is on the limit's open side.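

Compound 3, like compound 1 and compound 2, stands only at a limit, so no step among these compounds can be read in this assay: the limit of > 30000 nM in this assay, at which 3 of the 3 values shown sit. The compounds shown leave open whether any group on this amine nitrogen gives a value inside the range of this assay.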